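Swapping chloro for methoxy on the thiazole-linked aryl ring

The source may report more compounds than this note shows. Statements on the series, on what has been measured and on what is new or still open speak of the compounds shown alone.

Measured so far:
compound 1, `Cc1nc(-c2ccc(Cl)cc2)sc1C(=O)CSc1nc(N)c(C#N)c(-c2ccc(Cl)cc2)n1`, 15.5%
compound 2, `COc1ccc(-c2nc(SCC(=O)c3sc(-c4ccccc4)nc3C)[nH]c(=O)c2C#N)cc1OC`, 21.4%

Of the compounds shown here, two have been tested in a functional assay on U-87MG ATCC cells for antiproliferative activity against U-87 MG (Homo sapiens), read by MTT assay, with a stated time of 48 h, tested at 50 uM; a higher number here means a weaker effect of the compound at the concentration tested, a lower number a stronger effect. Compound 1 gives the lowest of the two numbers, at 15.5%, and compound 2 comes closest, at 21.4%, a gap that lies within the usual scatter, so nothing can be said about an order between them. For the measured compounds named here, compound 2 differs from compound 1 in more than one place, so no single step can be drawn between the two.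

Compound 3, `COc1ccc(-c2nc(C)c(C(=O)CSc3nc(N)c(C#N)c(-c4ccc(Cl)cc4)n3)s2)cc1`, has not yet been measured in this assay . It is derived from compound 1 by a single change, (methoxy in place of chloro on an aromatic carbon), sitting para to a large group. Going by the values given here, no measured pair shows what such a change does here. Among the compounds with values here, with no step of this kind on record, the expected step from compound 1 to compound 3 is a number 4.5 percentage points higher from compound 1 to compound 3 (within the scatter), that is, no change beyond the scatter, with a slight lean toward a higher number. Compound 3 is therefore estimated at 20%, within a range from 8% to 38%.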

Compound 3, a percentage reported as activity, at one concentration (the size of the read-out at that concentration, not a potency): 23.1%
Compound 3: the middle estimate sits 3.1 percentage points below what was measured; low and high end bracket the measured number.
By their numbers in this assay, from the lowest: compounds 1, 2 and 3 (each within the scatter of the next).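

For the compounds shown here, the step of a number 7.6 percentage points higher from compound 1 to compound 3 (within the scatter) is the first comparison in this assay between two compounds that differ in one place, and it puts a first measured size on a change at this position. Going from 4-chlorophenyl to 4-methoxyphenyl, on an aromatic carbon para to a large group, adds a heavy atom and a hydrogen-bond acceptor, yet the read-out at the single concentration tested does not move beyond the usual scatter, so this one swap gives no sign that the position is sensitive to the change. Nothing available offers an explanation for this outcome.

From the compounds shown here alone, whether a group of a different kind at this place, such as an amine, a carboxylic acid or a longer alkoxy chain, would shift the number beyond the scatter remains open. Going by these compounds, it is equally open whether the same swap on the second 4-chlorophenyl group of compound 1 would behave in the same way, and whether a comparison across several concentrations would separate compound 1 from compound 3.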